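The source may report more compounds than this note shows. Statements on the series, on what has been measured and on what is new or still open speak of the compounds shown alone.

Measured compounds:
- compound 1 `CCCCCc1ccc(-c2oc3nc(=O)n([C@H]4C[C@H](OC(C)=O)[C@@H](COC(C)=O)O4)cc3c2C#Cc2ccc(C)cc2)cc1`: 100000 nM
- compound 2 `CC(=O)OC[C@H]1O[C@@H](n2cc3c(C#CCCN4C(=O)c5ccccc5C4=O)c(-c4ccc(C)cc4)oc3nc2=O)C[C@@H]1OC(C)=O`: 100000 nM
- compound 3 `CCCCCc1ccc(-c2oc3nc(=O)n([C@H]4C[C@H](OC(C)=O)[C@@H](COC(C)=O)O4)cc3c2C#CCCO)cc1`: 100000 nM

In an ADME assay on HEL cells (Homo sapiens) for cytotoxicity, read by cell counting, with a stated time of 3 days (on this read-out higher numbers stand for lower toxicity in this test and lower numbers for higher toxicity in this test), compound 1 gives 100000 nM, compound 2 gives 100000 nM and compound 3 gives 100000 nM. Compound 2 stands level with both of the others at the digits shown, and the one step that can be followed, no change at the digits printed from compound 1 to compound 3 (within the scatter), brought no change within the scatter when a 2-hydroxyethyl replaced a 4-methylphenyl on a triple-bonded carbon.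

The account now turns to compound 4 `CC(=O)OC[C@H]1O[C@@H](n2cc3c(C#CCO)c(-c4ccc(C)cc4)oc3nc2=O)C[C@@H]1OC(C)=O`, which has not yet been tested in this assay. It differs from compound 2 by one oxygen atom in place of a group of 12 heavy atoms (9 carbon, 1 nitrogen, 2 oxygen; one five-membered non-aromatic ring with 1 hetero atom, one six-membered aromatic ring of carbon only), on a saturated chain carbon bound to a triple-bonded carbon. Within the data shown here, the only step that bears on this, that from compound 1 to compound 3, also exchanged a group on the triple-bonded carbon for a small hydroxy-bearing chain and left the read-out unchanged; compound 2 itself sits at the same level. Since no measured change on that chain has moved the read-out, no step beyond the scatter is expected, so that no change at the digits printed from compound 2 to compound 4 (within the scatter) is estimated as essentially flat. Compound 4 is therefore expected to give about 100000 nM, within a range of 50000 nM to 200000 nM.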

Compound 4, minimum cytotoxic concentration: > 100000 nM
Compound 4 was reported as a limit; the forecaster's own chance of this, stated with the estimate: 30%; the middle value lies on the limit itself.
By their numbers in this assay, from the lowest: compounds 1, 2 and 3 (each within the scatter of the next).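

In this assay compound 4 is reported as > 100000 nM, which is a limit and not a number. With a hydroxy in place of the group of 12 heavy atoms, on a saturated chain carbon bound to a triple-bonded carbon, the result is a number no lower from compound 2 to compound 4 (the limit leaves the size open). This place therefore carries both the large group with its two rings and a lone hydroxy without a lower number, something the earlier compounds did not show, although the size of the step stays unread: the limit of > 100000 nM in this assay, at which 1 of the 4 values shown sits.

On these data alone, whether an amine or a carboxylic acid on that carbon would bring the number down in this assay remains open. The same holds for a longer chain ending in a hydroxy.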